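This account rests on a few compounds, and the source may have more. Where it says the series, first, only, none or still open, it means among the compounds named here.

Measured compounds: compound 1 `O=C(NCc1ccccc1)c1cn(-c2ccccc2)nc1-c1cccnc1` gave "nd(insoluble)" (no result reported) in a functional assay on Raji cells (Homo sapiens) for cytotoxicity, read by MTT assay, with a stated time of 48 h; on this read-out lower numbers stand for stronger inhibition and higher numbers for weaker inhibition; compound 2 `O=C(c1cn(-c2ccccc2)nc1-c1cccnc1)N1CCC(Cc2ccccc2)CC1` gave 8120 nM in this assay.

Compound 1 stands nowhere on the numbers: no result was obtained for it, so no value can be placed beside compound 2. Compound 3 `COc1ccc(OC(=O)c2cn(-c3ccccc3)nc2-c2cccnc2)cc1` differs from compound 1 by 4-methoxyphenoxy in place of benzylamino on a carbonyl carbon. Among the compounds with values here, with no measured pair bridging this change, no direction or size of step can be drawn from the data. Given that the only number available, for compound 2, sits at weak inhibition, compound 3 is expected to remain weak and is estimated at 10000 nM, in a range from 3000 nM to 30000 nM.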

Compound 3, half-maximal inhibitory concentration: > 100000 nM
Compound 3: only a limit was reported (the forecaster's own chance of this, stated with the estimate: 35%); at least 10-fold (1.00 log units) between middle value and limit.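

Compound 3 gives only a limit, > 100000 nM. With no single number for compound 1 either, no step can be read between compound 1 and compound 3. As far as these compounds go, how far 4-methoxyphenoxy in place of benzylamino shifts the result in this assay stays open.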